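Moving a chloro group on the dichlorophenyl amide

The compounds below may be only part of what the source reports. "The series", "measured", "known", "first", "only" and "open" are said of these compounds alone.

Compound 1 `Cc1cc(C#N)cc(C)c1Oc1ccnc(S(=O)(=O)CC(=O)Nc2cccc(Cl)c2)n1` gives 25400 nM in an ADME assay on MT4 cells (Homo sapiens) for cytotoxicity, read by MTT assay, with a stated time of 4 days (a higher number here means that more compound is tolerated, a lower number that less compound is tolerated), and compound 2 `Cc1cc(C#N)cc(C)c1Oc1ccnc(S(=O)(=O)CC(=O)Nc2ccc(Cl)cc2)n1` gives 16600 nM. Compound 3 `Cc1cc(C#N)cc(C)c1Oc1ccnc(S(=O)(=O)CC(=O)Nc2ccc(Cl)c(Cl)c2)n1` gives 11700 nM, which sets it clearly apart only from compound 1, as a 2.2-fold lower number from compound 1 to compound 3 (0.34 log units; beyond the scatter) shows. Its gap to compound 2 is small, with a 1.4-fold lower number from compound 2 to compound 3 (0.15 log units; within the scatter).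

Compound 4 `Cc1cc(C#N)cc(C)c1Oc1ccnc(S(=O)(=O)CC(=O)Nc2cc(Cl)cc(Cl)c2)n1` has the same atoms as compound 3, joined differently: 3,5-dichlorophenyl in place of 3,4-dichlorophenyl on an amide-type nitrogen. In short, 3,5-dichlorophenyl stands in place of 3,4-dichlorophenyl on an amide-type nitrogen.

The closest measured parallel is another change in which the atoms stay the same, a 1.5-fold lower number from compound 1 to compound 2 (0.18 log units; within the scatter). That step is small, and so is the one just given for adding a chloro group to compound 2. Within the data shown here, with only three measured compounds, this is thin evidence, but it gives no reason to expect a real shift in this assay. The expected change is a 1.2-fold higher number from compound 3 to compound 4 (0.08 log units; within the scatter), no step beyond the scatter. For compound 4 the estimated value is 14000 nM, with an expected range of 7000 nM to 28000 nM.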

Compound 4, half-maximal cytotoxic concentration: 24000 nM
The estimate for compound 4 lay 1.7-fold (0.23 log units) below the measured number, within the range that was stated.
By their numbers in this assay, from the lowest: compounds 3, 2, 4 and 1 (each within the scatter of the next, the first and the last beyond it).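

Moving a chloro group without changing any atoms can on its own give a step beyond the scatter in this assay: a 2.1-fold higher number from compound 3 to compound 4 (0.31 log units; beyond the scatter). Among these compounds, compound 4 does not stand apart from the two compounds with one chloro group, as a 1.4-fold higher number from compound 2 to compound 4 (0.16 log units; within the scatter) and a 1.1-fold lower number from compound 1 to compound 4 (0.02 log units; within the scatter) show, so the 3,4-dichlorophenyl of compound 3 is the only group here that separates clearly from compound 1. Adding a chloro group gives a small step in two of the three cases, the exception being a 2.2-fold lower number from compound 1 to compound 3 (0.34 log units; beyond the scatter), and the two small steps agree: the same change on two cores in this assay, a 1.4-fold lower number (0.15 log units; within the scatter) from compound 2 to compound 3 and a 1.1-fold lower number (0.02 log units; within the scatter) from compound 1 to compound 4, 1.3-fold (0.13 log units) apart, within the scatter of two such steps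

The step between the two dichlorophenyl groups has been seen only once, and it is modest. On these data alone, the effect of a methoxy group or an amine in place of chloro on this phenyl ring remains open.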